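The source may hold more compounds than are shown below. What is called first, only, known or untested is meant among the compounds shown, and "the series" means these compounds.

Compound 1 `O=C1CSC(N2N=C(c3ccc(Cl)cc3)CC2c2ccc3ccccc3c2)=N1` is measured in a functional assay on HepG2 cells (Homo sapiens) for inhibition, read by CCK-8 assay, with a stated time of 48 h (on this read-out lower numbers stand for stronger inhibition and higher numbers for weaker inhibition), at 20400 nM. Among the three compounds measured so far it holds the second highest number: its nearest neighbour is compound 2 `Clc1ccc(C2=NN(C3=NC(c4ccccc4)CS3)C(c3ccc4ccccc4c3)C2)cc1`, which in this assay gives 22100 nM, and the furthest is compound 3 `Cc1ccc(C2=NN(C3=NC(c4ccccc4)CS3)C(c3cccc4ccccc34)C2)cc1C`, which in this assay gives 7250 nM. The one step that joins two of these compounds by a single change is a 1.1-fold higher number from compound 1 to compound 2 (0.03 log units; within the scatter), a change on an amine nitrogen in a ring that left the read-out essentially where it was.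

Compound 4 `Cc1ccc(C2=NN(C3=NC(=O)CS3)C(c3ccc4ccccc4c3)C2)cc1C` is the not yet measured compound. It differs from compound 1 as follows: 3,4-dimethylphenyl in place of 4-chlorophenyl on a carbon with a double bond to nitrogen. Going by the values given here, no measured pair differs by this change alone. Compound 2 and compound 3 do differ at this position, but they also differ in the naphthalene attachment, so their two values can only be read as a loose hint that the dimethyl pattern went with a lower number. On that basis only a modest downward movement is expected, a 1.7-fold lower number from compound 1 to compound 4 (0.23 log units; within the scatter), with real uncertainty about whether it will clear the scatter at all. Compound 4 is therefore estimated at 12000 nM, within a range from 4000 nM to 35000 nM.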

Compound 4, half-maximal inhibitory concentration: 8490 nM
Compound 4: the middle estimate sits 1.4-fold (0.15 log units) above what was measured; measured number inside the range.
By their numbers in this assay, from the lowest: compounds 3 and 4 (each within the scatter of the next); then compounds 1 and 2 (each within the scatter of the next).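

Going by these compounds alone, replacing 4-chlorophenyl with 3,4-dimethylphenyl gives the first direct reading of this position in this assay: a 2.4-fold lower number from compound 1 to compound 4 (0.38 log units; beyond the scatter), a modest step that lies beyond the scatter, so the aryl group on the carbon with a double bond to nitrogen does bear on the read-out. The only earlier single-place step, made on the amine nitrogen in a ring, stayed within the scatter, so this is the first single change among these compounds that moves the number measurably, and it does so although neither group carries hydrogen-bond donors, hydrogen-bond acceptors or a net charge. No evidence is available here that would explain the step.

The compounds shown leave open whether the step follows the loss of the chlorine or the arrival of the methyl groups, and whether either methyl group alone, as in a 3-methylphenyl or 4-methylphenyl, or a plain phenyl would give the same number. They also leave open how far this position tolerates a different kind of substituent, such as an amine or a carboxylic acid on the phenyl ring, and whether the same exchange would move the number on the core of compound 2.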